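Swapping a dichlorophenyl for a methoxyphenyl on a diketopiperazine-type scaffold

The source may report more compounds than this note shows. Statements on the series, on what has been measured and on what is new or still open speak of the compounds shown alone.

Compound 3 `C=CCn1c(=O)/c(=C\c2ccc(Cl)c(Cl)c2)[nH]c(=O)/c1=C\c1ccccc1OC` was reported as "not active" (no number reported) in a functional assay on NCI-H1975 cells (Homo sapiens) for cytotoxicity, read by CCK-8 assay, with a stated time of 72 h (a lower number here means a stronger inhibitor, a higher number a weaker inhibitor), with no number given. The neighbouring compounds give a sense of the scale: compound 1 `COc1ccccc1/C=c1/[nH]c(=O)/c(=C\c2ccccc2OC)n(C)c1=O` shows 16900 nM, and compound 2 `C=CCn1c(=O)/c(=C\c2cccc(F)c2)[nH]c(=O)/c1=C\c1ccccc1OC` shows 25600 nM in this assay. The change to compound 4 `C=CCn1c(=O)/c(=C\c2ccccc2OC)[nH]c(=O)/c1=C\c1ccccc1OC` is 2-methoxyphenyl in place of 3,4-dichlorophenyl on a double-bonded chain carbon bound to an aromatic carbon, which makes both arms of the core carry the same 2-methoxyphenyl group, as in compound 1. For the measured compounds named here, no step between measured compounds covers this change, so its size is a matter of expectation: an improvement from inactive into a measurable but weak range, because compound 1 gives 16900 nM with the same two arms. For compound 4 the expected value in this assay is 18000 nM, within a range of 7000 nM to 50000 nM.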

Compound 4, half-maximal inhibitory concentration: 21500 nM
Estimate against measurement, compound 4: 1.2-fold (0.08 log units) below; measured number inside the range.
By their numbers in this assay, from the lowest: compounds 1, 4 and 2 (each within the scatter of the next).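

In this assay, 2-methoxyphenyl on this carbon gives a measurable number where 3,4-dichlorophenyl on compound 3 gave none, although the size of that change cannot be read. The swap from 3-fluorophenyl is small (a 1.2-fold lower number from compound 2 to compound 4 (0.08 log units; within the scatter)), as is the added vinyl on the saturated chain carbon bound to an aromatic nitrogen (a 1.3-fold higher number from compound 1 to compound 4 (0.10 log units; within the scatter)), so neither change separates these compounds. No evidence is available to explain these results.

Going by these compounds, it remains open whether a single chlorine, as in 4-chlorophenyl, would give a measurable number here. A longer chain on that aromatic nitrogen is also untested among these compounds.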